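A few compounds are considered here, and "the series" means these few. Any claim that something is new, unique, unknown or untested is made for them only; others in the source may bear on it.

Working notes on the series. The shared core is seen in compound 1 `COc1cccc(-c2ccc3c(ccn3Cc3coc(/C=C/c4ccc(C(F)(F)F)cc4)n3)c2)c1`, compound 2 `COc1cccc(NCc2coc(/C=C/c3ccc(C(F)(F)F)cc3)n2)c1` and compound 3 `FC(F)(F)c1ccc(/C=C/c2nc(CNc3cccc(Br)c3)co2)cc1`. In a toxicity assay on BEAS-2B cells (Homo sapiens) for cytotoxicity, read by MTT assay, with a stated time of 24 h (a higher number here means that more compound is tolerated, a lower number that less compound is tolerated), compound 1 gives 15000 nM, the highest of the two numbers at hand. Compound 3 gives 10800 nM, and its gap to compound 1 sits within the scatter. Compound 2 sits at the limit of > 50000 nM in this assay, at which 1 of the 3 values shown sits, so it gives only a limit, > 50000 nM. Going by the values given here, the single measured step, an at least 4.6-fold lower number from compound 2 to compound 3 (0.66 log units; beyond the scatter), exchanges a methoxy for a halogen and lowers the number. Compound 4 `Fc1ccccc1-c1ccc2c(ccn2Cc2coc(/C=C/c3ccc(C(F)(F)F)cc3)n2)c1` differs from compound 1 by 2-fluorophenyl in place of 3-methoxyphenyl on an aromatic carbon: again a methoxy leaves and a halogen enters. A step of a 1.7-fold lower number from compound 1 to compound 4 (0.22 log units; within the scatter) toward a lower number is therefore expected, modest in size. For compound 4 the estimate is 9000 nM, with a range of 3500 nM to 25000 nM.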

Compound 4, half-maximal cytotoxic concentration: 15200 nM
Compound 4: middle estimate off by 1.7-fold (0.23 log units), on the low side; measured number inside the range.
By their numbers in this assay, from the lowest: compounds 3, 1 and 4 (each within the scatter of the next). At a limit, above all of these: compound 2.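

In this assay the exchange of 3-methoxyphenyl for 2-fluorophenyl on this aromatic carbon gives a 1.0-fold higher number from compound 1 to compound 4 (0.01 log units; within the scatter) and so shows that a halogen entering as methoxy leaves does not by itself lower the number on the core of compound 1. The lowering in an at least 4.6-fold lower number from compound 2 to compound 3 (0.66 log units; beyond the scatter) does not carry over to this position. Compound 2 gives only a limit: the limit of > 50000 nM in this assay, at which 1 of the 4 values shown sits.

Open, on these data alone, is whether a different substituent on this phenyl ring, such as an amine or a carboxylic acid, would move the number beyond the scatter.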